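Cytotoxicity in the series: chloro replaces acetyl

The compounds below may be only part of what the source reports. "The series", "measured", "known", "first", "only" and "open" are said of these compounds alone.

Compound 1 `O=C(c1ccc(NCc2cncn2Cc2ccc(-c3ccccc3)cc2)cc1-c1ccccc1)N1CCCCC1`, compound 2 `c1ccc(-c2ccc(Cn3cncc3CNc3ccc(-c4cncs4)c(-c4ccccc4)c3)cc2)cc1` and compound 3 `CC(=O)c1ccc(NCc2cncn2Cc2ccc(-c3ccccc3)cc2)cc1-c1ccccc1` share one core and were read in a toxicity assay on NIH3T3 cells (Mus musculus) for cytotoxicity, read by resazurin assay; a higher number here means that more compound is needed for the effect, a lower number that less compound is needed. For compound 1 the result is a limit of the assay, > 1000 nM. For compound 2 the result is likewise a limit, > 1000 nM. Compound 3 also reaches only a limit, > 10000 nM. Compound 3 thus stands at a limit, as do the two other values shown (the limit of > 1000 nM in this assay, at which 2 of the 3 values shown sit; (the limit of > 10000 nM in this assay, at which 1 of the 3 values shown sits)). The steps a step that the two limits leave unreadable from compound 1 to compound 2, a step that the two limits leave unreadable from compound 1 to compound 3 and a step that the two limits leave unreadable from compound 2 to compound 3 are all unreadable in size, so none of them gives a readable size for the change to compound 4 `Clc1ccc(NCc2cncn2Cc2ccc(-c3ccccc3)cc2)cc1-c1ccccc1`: chloro in place of acetyl on an aromatic carbon. In this assay no step beyond the scatter is expected, a step that the limit leaves unreadable from compound 3 to compound 4. Compound 4 is estimated at 20000 nM, with a range of 3000 nM to 100000 nM, and will most likely again be reported only as a limit.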

Compound 4, half-maximal effective concentration: > 1000 nM
Compound 4 ended at the assay's limit; the forecaster's own chance of this, stated with the estimate: 85%; the middle value lies beyond the limit too.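

The steps from compound 1, compound 2 and compound 3 to compound 4 cannot be read, as all four compounds stand only at limits in this assay. Open remains the concentration at which any of them takes effect, and whether chloro, acetyl, 1,3-thiazol-5-yl and (piperidin-1-yl)carbonyl differ at all.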